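Aryl urea series: ester in place of trifluoromethyl

This account rests on a few compounds, and the source may have more. Where it says the series, first, only, none or still open, it means among the compounds named here.

Among the compounds with values here, the three measured members are compound 1 `CCc1ccc(NC(=O)N[C@H](C)c2ccccc2)cc1`, compound 2 `CC(C)c1ccc(NC(=O)N[C@H](C)c2ccccc2)cc1` and compound 3 `C[C@@H](NC(=O)Nc1ccc(C(F)(F)F)cc1)c1ccccc1`, all on the shared urea core. In an ADME assay on the whole organism with Oryza sativa as the target, tested at 10 uM (on this read-out higher numbers stand for a weaker effect at the one concentration tested and lower numbers for a stronger effect), compound 1 gives 44%, compound 2 gives 49% and compound 3 gives 82%. Compound 3 has the highest number of the three in this assay; the nearest is compound 2 and the furthest is compound 1, both beyond the scatter. Between the two alkyl-bearing members the step of a number 5 percentage points higher from compound 1 to compound 2 (within the scatter) stays within the scatter.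

Compound 4 `CCOC(=O)c1ccc(NC(=O)N[C@H](C)c2ccccc2)cc1` is not yet measured. It differs from compound 3 as follows: ethoxycarbonyl in place of trifluoromethyl on an aromatic carbon. Within the data shown here, two measured steps change the same aromatic carbon, a number 38 percentage points higher from compound 1 to compound 3 (beyond the scatter) and a number 33 percentage points higher from compound 2 to compound 3 (beyond the scatter); both are large, and each runs toward trifluoromethyl, so the change here is the first that removes it. Among the measured compounds shown here, no measured compound carries an ethoxycarbonyl group, so the expectation rests only on those two steps and is loose. Removal of trifluoromethyl is expected to move the number back toward the alkyl-bearing members; the expected step is a number 20 percentage points lower from compound 3 to compound 4 (beyond the scatter). For compound 4 in this assay the estimate is 62%, with a range from 38% to 88%.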

Compound 4, a percentage reported as activity, at one concentration (the size of the read-out at that concentration, not a potency): 92%
Estimate against measurement, compound 4: 30 percentage points below; the measured number lies above the stated range.
By their numbers in this assay, from the lowest: compounds 1 and 2 (each within the scatter of the next); then compounds 3 and 4 (each within the scatter of the next).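

In this assay, ethoxycarbonyl in place of trifluoromethyl on an aromatic carbon, para to a large group, gives a number 10 percentage points higher from compound 3 to compound 4 (within the scatter), so this read-out does not separate the two groups, although the entering group has more heavy atoms and carries hydrogen-bond acceptors. Against the alkyl-bearing members the same group gives a number 43 percentage points higher from compound 2 to compound 4 (beyond the scatter) and a number 48 percentage points higher from compound 1 to compound 4 (beyond the scatter), so the large separation from ethyl and isopropyl is no longer tied to trifluoromethyl alone, and among these four compounds, with none going against it, the position divides into two alkyl groups on one side and trifluoromethyl and ethoxycarbonyl on the other. Nothing available on these compounds accounts for that division.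

Still open, going by these compounds, is where a nitrile, a methoxy group, a carboxylic acid or a primary amide on the same aromatic carbon would fall relative to these two sets, and whether a methyl ester or a longer ester chain would stay with ethoxycarbonyl. Also open, on these data alone, is whether the division survives a change elsewhere on the shared core, which is constant across all four compounds.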